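A few compounds are considered here, and "the series" means these few. Any claim that something is new, unique, unknown or untested is made for them only; others in the source may bear on it.

Compound 2 `COc1ccccc1-n1nncc1CN1C(=O)C2(C(C#N)=C(N)Oc3c2c2nc4ccccc4nc2c2ccccc32)c2ccccc21` is one of two members of the series with a value in a functional assay on A549 cells (Homo sapiens) for antiproliferative activity, read by MTT assay, with a stated time of 48 h; a higher number here means a weaker inhibitor, a lower number a stronger inhibitor. In this assay compound 2 gives > 50000 nM, which is a limit of the assay and not a number. Compound 1 `COc1ccc(-n2nncc2CN2C(=O)C3(C(C#N)=C(N)Oc4c3c3nc5ccccc5nc3c3ccccc43)c3ccccc32)cc1` carries 4-methoxyphenyl on an aromatic nitrogen where compound 2 carries 2-methoxyphenyl. In this assay compound 1 gives > 50000 nM, again a limit. Among the measured compounds shown here, the single measured step, a step that the two limits leave unreadable from compound 1 to compound 2, is therefore of unreadable size, and the limit of > 50000 nM in this assay, at which 2 of the 2 values shown sit, is all that the two values show. Compound 3 `N#CC1=C(N)Oc2c(c3nc4ccccc4nc3c3ccccc23)C12C(=O)N(Cc1cnnn1-c1ccc(F)c(Cl)c1)c1ccccc12` differs from compound 2 by 3-chloro-4-fluorophenyl in place of 2-methoxyphenyl on an aromatic nitrogen. For the measured compounds named here, the one measured step touches the same aromatic nitrogen but yields no readable size, so no direction can be drawn from it; the expected step that the limit leaves unreadable from compound 2 to compound 3 rests on two limits alone. Compound 3 is estimated at 60000 nM in this assay, with a range of 20000 nM to 200000 nM, most likely reported once more as a limit.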

Compound 3, half-maximal inhibitory concentration: > 50000 nM
Compound 3 gave a limit, no number; the forecaster's own chance of this, stated with the estimate: 75%; the middle value does not contradict the limit.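

In this assay, among the compounds shown here, compound 3 gives > 50000 nM, a limit of the assay and not a number, so no step among compound 1, compound 2 and compound 3 can be read. The compounds shown leave open whether any group on this aromatic nitrogen gives a readable value: the limit of > 50000 nM in this assay, at which 3 of the 3 values shown sit.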